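A few compounds are considered here, and "the series" means these few. Any claim that something is new, unique, unknown or untested is made for them only; others in the source may bear on it.

In a functional assay on K562 cells (Homo sapiens) for antiproliferative activity, read by MTT assay, with a stated time of 48 h (on this read-out lower numbers stand for stronger inhibition and higher numbers for weaker inhibition), compound 1 (`COc1ccc(-c2ccc3c(c2)C(=O)C(=O)N3C)cc1`), which carries a methyl on the amide-type nitrogen in a ring, gives 4980 nM. Compound 2 (`COc1ccc(-c2ccc3c(c2)C(=O)C(=O)N3c2ccc(OC)cc2)cc1`) reaches only a limit of the assay, > 10000 nM. Compound 3 (`COc1ccc(-c2ccc3c(c2)C(=O)C(=O)N3Cc2ccc(Cl)c(Cl)c2)cc1`) gives 430 nM, the lowest number of the three, and both steps leading to it are large: a 12-fold lower number from compound 1 to compound 3 (1.06 log units; beyond the scatter) and an at least 23-fold lower number from compound 2 to compound 3 (1.36 log units; beyond the scatter). Compound 4 (`COc1ccc(-c2ccc3c(c2)C(=O)C(=O)N3Cc2ccccc2Cl)cc1`) changes only the aryl group of compound 3, with 2-chlorophenyl in place of 3,4-dichlorophenyl on a saturated chain carbon bound to an amide-type nitrogen in a ring. Within the data shown here, no measured step isolates this change. The nearest guide is a 12-fold lower number from compound 1 to compound 3 (1.06 log units; beyond the scatter), since compound 4 keeps the chain carbon but not the full 3,4-dichlorophenyl group. Most of that gain is therefore expected to survive in this assay, with a modest loss. The expected change is a 2.1-fold higher number from compound 3 to compound 4 (0.32 log units; beyond the scatter). For compound 4 the estimated value is 900 nM, with an expected range of 300 nM to 2800 nM.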

Compound 4, half-maximal inhibitory concentration: 380 nM
For compound 4 the middle estimate is 2.4-fold (0.37 log units) above the measured one; the measured number falls inside the stated range.
By their numbers in this assay, from the lowest: compounds 4 and 3 (each within the scatter of the next); then compound 1. At a limit, above all of these: compound 2.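

In this assay, 2-chlorophenyl in place of 3,4-dichlorophenyl on a saturated chain carbon bound to an amide-type nitrogen in a ring gives a 1.1-fold lower number from compound 3 to compound 4 (0.05 log units; within the scatter), so these two chlorine patterns are not separated here. The large step from the methyl on this nitrogen therefore does not require the 3,4-dichlorophenyl group, since the 2-chlorophenyl group also gives a 13-fold lower number from compound 1 to compound 4 (1.12 log units; beyond the scatter). The 2-chlorobenzyl group in place of 4-methoxyphenyl on this nitrogen gives an at least 26-fold lower number from compound 2 to compound 4 (1.42 log units; beyond the scatter), a step that starts from a limit of the assay and not from a number: the limit of > 10000 nM in this assay, at which 1 of the 4 values shown sits.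

Whether any chlorine is needed remains open, as the compounds shown do not include a plain benzyl group on this nitrogen. As far as these compounds go, what a 2-phenylethyl group, with its longer chain, or an amine on the aryl ring would give is also open.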